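The compounds below may be only part of what the source reports. "The series", "measured", "known", "first", "only" and "open" are said of these compounds alone.

Working notes on the pyrrolidine amide series.

Compound 1 `Cc1ccc(CCCCCCC(=O)N2CCCC2)cc1` gives 9600 nM in an assay on HEK293 cells for inhibition of N-acylethanolamine-hydrolyzing acid amidase (Rattus norvegicus), read by LC-MS, with a stated time of 30 min; a lower number here means a stronger inhibitor, a higher number a weaker inhibitor. Compound 3 `COC(=O)c1ccc(CCCCCCC(=O)N2CCCC2)cc1` returns only a limit in this assay, > 100000 nM. The step of an at least 10-fold higher number from compound 1 to compound 3 (1.01 log units; beyond the scatter) runs into (the limit of > 100000 nM in this assay, at which 2 of the 3 values shown sit), so its true size is not known. Compound 2 `O=C(CCc1ccc(-c2ccccc2Cl)cc1)N1CCCC1` also returns only a limit in this assay, > 100000 nM; it therefore stands at the weak end of the numbers shown, with no measured value of its own.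

Compound 4 `O=C(CCc1ccc(OC2CCCCC2)cc1)N1CCCC1` carries cyclohexyloxy in place of 2-chlorophenyl on an aromatic carbon. For the measured compounds named here, no measured pair covers this change; the single measured step concerns a different position and is itself truncated by the limit, so it gives no guide to direction. Compound 4 is expected near 8000 nM, within 800 nM to 100000 nM. That estimate implies an expected step of an at least 12-fold lower number from compound 2 to compound 4 (1.09 log units; beyond the scatter), uncertain in sign.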

Compound 4, half-maximal inhibitory concentration: 700 nM
Estimate against measurement, compound 4: 11-fold (1.06 log units) above; the measured number lies below the stated range.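

At this aromatic carbon, para to a group of 9 heavy atoms, cyclohexyloxy in place of 2-chlorophenyl gives an at least 140-fold lower number from compound 2 to compound 4 (2.15 log units; beyond the scatter) in this assay, the only step shown toward a lower number. Its true size stays unknown, as compound 2 sits at a limit: the limit of > 100000 nM in this assay, at which 2 of the 4 values shown sit.

The two groups share a heavy-atom count and a six-membered ring of carbon only, so the step goes with the ring being non-aromatic, the oxygen, or both.

Phenoxy and cyclohexyl at this position would separate those two. Also open, from the compounds shown here alone, is how cyclohexyloxy behaves on the longer chain of compound 1.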